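This account rests on a few compounds, and the source may have more. Where it says the series, first, only, none or still open, it means among the compounds named here.

Compound 1 `COc1ccc(/C=C\c2cc(OC)c(OC)c(OC)c2)cc1OCc1ccc(CN2CCCC[C@H]2C(=O)O)cc1` in an ADME assay on NCM460 cells (Homo sapiens) for cytotoxicity, read by CCK-8 assay, with a stated time of 48 h (on this read-out higher numbers stand for weaker inhibition and lower numbers for stronger inhibition), gives > 50000 nM, which is a limit of the assay and not a number.
Compound 2 `COc1ccc(/C=C\c2cc(OC)c(OC)c(OC)c2)cc1OCc1ccc(CNCCNC(C)=O)cc1` in this assay gives 54000 nM.

Compound 1 stands only at a limit in this assay, as the limit of > 50000 nM in this assay, at which 1 of the 2 values shown sits, shows, so its place among the numbers is not fixed. Going by the values given here, the one measured step, a step that the limit leaves unreadable from compound 1 to compound 2, cannot be read in size because compound 1 sits at the limit of > 50000 nM in this assay, at which 1 of the 2 values shown sits; it shows only that compound 2 lies close to that limit. The unmeasured compound 3 `COc1ccc(/C=C\c2cc(OC)c(OC)c(OC)c2)cc1OCc1ccc(CN2CC[C@@H](C(=O)O)C2)cc1` differs from compound 1 by 3-carboxypyrrolidin-1-yl in place of 2-carboxypiperidin-1-yl on a saturated chain carbon bound to an aromatic carbon. Among the compounds with values here, no measured step covers this change, and the single step available is unreadable, so no direction beyond the scatter is expected. Compound 3 is therefore expected to sit close to the limit, with an estimated step that the limit leaves unreadable from compound 1 to compound 3. The expected value for compound 3 is 55000 nM, with a range of 25000 nM to 150000 nM.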

Compound 3, half-maximal inhibitory concentration: > 50000 nM
Compound 3 ended at the assay's limit (the forecaster's own chance of this, stated with the estimate: 60%); the middle value lies beyond the limit too.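

The steps from compound 3 to compound 1 and compound 2 cannot be read in size, since these values stop at: the limit of > 50000 nM in this assay, at which 2 of the 3 values shown sit.

The compounds shown leave open how far compound 1 and compound 3 lie past that limit, and whether 3-carboxypyrrolidin-1-yl and 2-carboxypiperidin-1-yl differ at all in this assay.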